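This account rests on a few compounds, and the source may have more. Where it says the series, first, only, none or still open, it means among the compounds named here.

Working notes on the series. Compound 1 `COc1cc(-c2cc(/C=C/C(=O)c3ccc(Cl)c(Cl)c3)[nH]n2)cc(OC)c1OC` and compound 2 `COc1ccc(C(=O)/C=C/c2cc(-c3cc(OC)c(OC)c(OC)c3)n[nH]2)cc1OC` share one core and differ only in the aryl group on the carbonyl carbon. In a functional assay on Malme-3M cells (Homo sapiens) for cytotoxicity, read by sulforhodamine B assay, with a stated time of 48 h, tested at 0.01 uM (a lower number here means a stronger effect, a higher number a weaker effect of the compound at the concentration tested), compound 1 gives 94%. In this assay compound 2 gives 95%; the two numbers lie within the scatter of each other, so compound 2 cannot be set apart from compound 1 on these data. Going by the values given here, the only measured step, a number 1 percentage points higher from compound 1 to compound 2 (within the scatter), puts 3,4-dimethoxyphenyl in place of 3,4-dichlorophenyl on the carbonyl carbon without moving the read-out beyond the scatter.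

Compound 3 `COc1cc(-c2cc(/C=C/C(=O)c3ccc(F)c(F)c3)[nH]n2)cc(OC)c1OC` is not yet measured. It differs from compound 2 by 3,4-difluorophenyl in place of 3,4-dimethoxyphenyl on a carbonyl carbon. The step from compound 1 to compound 2 bears on this change, since it also exchanges the aryl group on the carbonyl carbon, and it was flat within the scatter. On that basis the expected step of a number 1 percentage points lower from compound 2 to compound 3 (within the scatter) in this assay is none beyond the scatter. The estimate for compound 3 in this assay is therefore 94%, with a range from 84% to 103%.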

Compound 3, a percentage reported as activity, at one concentration (the size of the read-out at that concentration, not a potency): 93%
Estimate against measurement, compound 3: 1 percentage points above; the measured number falls inside the stated range.
By their numbers in this assay, from the lowest: compounds 3, 1 and 2 (each within the scatter of the next).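

At the aryl group on the carbonyl carbon, the series now holds a third substituent pattern, and the two new comparisons in this assay both stay within the scatter: the exchange gives a number 2 percentage points lower from compound 2 to compound 3 (within the scatter), and set against the dichloro analogue it gives a number 1 percentage points lower from compound 1 to compound 3 (within the scatter). Going by these compounds alone, the step from compound 2 to compound 3 is the first here that replaces 3,4-dimethoxyphenyl, with its 2 hydrogen-bond acceptors, by a group with 0 hydrogen-bond acceptors, 3,4-difluorophenyl, and the read-out still does not separate the two compounds. Compounds 1, 2 and 3 therefore cannot be set apart from one another at this single concentration, and nothing available accounts for this result.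

All three aryl groups shown carry their two substituents in the same pattern, so the effect of a different kind of group on the carbonyl carbon remains open. Whether a phenyl ring bearing an amine or a carboxylic acid, or a saturated cyclohexyl group, would move the read-out beyond the scatter in this assay cannot be told from these compounds.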